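A Flat Series Awaits Its Fluoro Member

The source may hold more compounds than are shown below. What is called first, only, known or untested is meant among the compounds shown, and "the series" means these compounds.

Of the compounds shown here, three sharing one core have been measured in a functional assay, read by Griess assay, with a stated time of 2.5 h; a higher number here means a weaker inhibitor, a lower number a stronger inhibitor. Compound 1 `COc1cc(OC)c(OC)cc1/C=C/C(=O)c1ccc(Cl)cc1` gives 2.01 ug/mL, compound 2 `COc1cc(OC)c(OC)cc1/C=C/C(=O)c1ccc(-c2c[nH]cn2)cc1` gives 1.97 ug/mL, and compound 3 `COc1cc(OC)c(OC)cc1/C=C/C(=O)c1cc(Cl)ccc1O` gives 2.32 ug/mL, which places compound 3 within the scatter of both others. Compound 4 `COc1cc(OC)c(OC)cc1/C=C/C(=O)c1ccc(F)cc1` has 4-fluorophenyl in place of 5-chloro-2-hydroxyphenyl on a carbonyl carbon. Going by the values given here, two measured steps bear on this change. The same place was altered in a 1.2-fold higher number from compound 1 to compound 3 (0.06 log units; within the scatter), and a different group replaced chloro in a 1.0-fold lower number from compound 1 to compound 2 (0.01 log units; within the scatter). Among the compounds with values here, no fluorinated compound has yet been measured. Neither step left the scatter, so the expected result is a 1.1-fold lower number from compound 3 to compound 4 (0.04 log units; within the scatter), with no real change in either direction. For compound 4 the estimated value is 2.1 ug/mL, with an expected range of 1.2 ug/mL to 3.6 ug/mL.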

Compound 4, half-maximal inhibitory concentration: 1.96 ug/mL
The estimate for compound 4 lay 1.1-fold (0.03 log units) above the measured number, within the range that was stated.
By their numbers in this assay, from the lowest: compounds 4, 2, 1 and 3 (each within the scatter of the next).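

The number in this assay stayed within the scatter with fluoro on this aromatic carbon: fluoro in place of chloro gave (a 1.0-fold lower number from compound 1 to compound 4 (0.01 log units; within the scatter)), and fluoro in place of 1H-imidazol-4-yl gave (a 1.0-fold lower number from compound 2 to compound 4 (0.00 log units; within the scatter)). Going from 5-chloro-2-hydroxyphenyl, with 1 hydrogen-bond donor, to 4-fluorophenyl, with 0 hydrogen-bond donors, gave (a 1.2-fold lower number from compound 3 to compound 4 (0.07 log units; within the scatter)), which also stays within the scatter. Nothing available explains why these changes leave the number in place. The compounds shown leave open whether an amine or a carboxylic acid on this aromatic carbon would move the number beyond the scatter.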